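From trifluoromethyl to amino: what compound 4 may show

The compounds below may be only part of what the source reports. "The series", "measured", "known", "first", "only" and "open" are said of these compounds alone.

Values in a physicochemical assay for solubility, measured as kinetic solubility, at pH 6.5; a lower number here means a less soluble compound, a higher number a more soluble compound:
- compound 1 `COc1ccc(-c2cc(-c3ccc(S(C)(=O)=O)cc3)cnc2NCCCCN)cn1` gives 25 ug/mL
- compound 2 `COc1ccc(-c2cc(-c3ccc(S(C)(=O)=O)cc3)cnc2C(F)(F)F)cn1` gives 12.5 ug/mL
- compound 3 `COc1ccc(-c2cc(-c3ccc(S(C)(=O)=O)cc3)ccc2N)cn1` gives 6.3 ug/mL

Compound 2, at 12.5 ug/mL, lies within the scatter of the other two compounds. Compound 4 `COc1ccc(-c2cc(-c3ccc(S(C)(=O)=O)cc3)cnc2N)cn1` differs from it by amino in place of trifluoromethyl on an aromatic carbon. For the measured compounds named here, the one measured step involving trifluoromethyl is a 2.0-fold lower number from compound 1 to compound 2 (0.30 log units; within the scatter), with trifluoromethyl in place of (4-aminobutyl)amino, and it stays within the scatter. On that evidence, no step beyond the scatter is expected in this assay, in either direction. The estimated step is a 1.0-fold lower number from compound 2 to compound 4 (0.02 log units; within the scatter). For compound 4 the estimate is 12 ug/mL, with an expected range of 5 ug/mL to 30 ug/mL.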

Compound 4, solubility: 121 ug/mL
Compound 4: the middle estimate sits 10-fold (1.00 log units) below what was measured, and the stated range ends below it.
By their numbers in this assay, from the lowest: compounds 3, 2 and 1 (each within the scatter of the next, the first and the last beyond it); then compound 4.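

In this assay, for the compounds shown here, the group at this position matters more than the earlier compounds suggested: amino in place of trifluoromethyl gives a 9.7-fold higher number from compound 2 to compound 4 (0.99 log units; beyond the scatter), whereas the earlier change here stayed within the scatter. Removing the 4-aminobutyl chain from the nitrogen, leaving hydrogen, gives a 4.8-fold higher number from compound 1 to compound 4 (0.68 log units; beyond the scatter), so the plain amino compound stands clearly above both neighbours. Nothing shown here explains these steps.

The compounds shown leave open whether a hydroxyl or methylamino group at this position would match amino. They also leave open how a shorter aminoalkyl chain on the nitrogen would compare.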